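The compounds below may be only part of what the source reports. "The series", "measured", "known", "first", "only" and "open" are said of these compounds alone.

Working notes on the guanidine series.

Compound 2 `N=C(NCCO)N1C[C@H](O)[C@@H](O)[C@H](O)[C@H]1CO` carries a hydroxy on the chain; in an assay on isolated protein for inhibition of alpha-galactosidase (Coffea arabica), read by spectrophotometry, with a stated time of 30 min (a higher number here means a weaker inhibitor, a lower number a stronger inhibitor), compound 2 gives 540000 nM, the highest of the two numbers in hand. Among the measured compounds shown here, compound 1 `CCCCCCCCNC(=N)N1C[C@H](O)[C@@H](O)[C@H](O)[C@H]1CO`, the nearest point, gives 23000 nM in this assay; the step of a 23-fold higher number from compound 1 to compound 2 (1.37 log units; beyond the scatter) is the only measured step and is large. The next compound, compound 3 `N=C(NCCCc1ccccc1)N1C[C@H](O)[C@@H](O)[C@H](O)[C@H]1CO`, differs from compound 2 by benzyl in place of hydroxy on a saturated chain carbon, two bonds along the chain from an amine nitrogen. The measured step bears on it directly: removing a hydrocarbon chain and leaving a hydroxy in its place raised the number sharply, so the reverse exchange of hydroxy for benzyl is expected to lower it by a large amount, of about the size seen between compound 1 and compound 2, with compound 1 as the anchor for where it should land. Compound 3 is therefore estimated to reach 40000 nM in this assay, with a range of 12000 nM to 130000 nM, a step of a 14-fold lower number from compound 2 to compound 3 (1.13 log units; beyond the scatter).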

Compound 3, half-maximal inhibitory concentration: > 1000000 nM
Compound 3 ended at the assay's limit; the forecaster's own chance of this, stated with the estimate: 3%; middle value at least 25-fold (1.39 log units) from the limit.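

Compound 3 gives > 1000000 nM in this assay, which is a limit of the assay and not a number: the limit of > 1000000 nM in this assay, at which 1 of the 3 values shown sits. The hydrocarbon chain of compound 1 cannot simply be traded for another hydrocarbon end at this position, since phenyl in place of pentyl gives an at least 43-fold higher number from compound 1 to compound 3 (1.63 log units; beyond the scatter). Benzyl in place of hydroxy gives an at least 1.8-fold higher number from compound 2 to compound 3 (0.26 log units; that floor lies within the scatter), so this change shows no lowering of the number, while the true size of the step, and any order between these two compounds, stays unread.

The compounds shown leave open whether the loss follows from the phenyl ring itself or from the shorter chain that carries it. A cyclohexyl ring at the same chain end, or a longer chain ending in phenyl, would separate those two readings.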